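This account rests on a few compounds, and the source may have more. Where it says the series, first, only, none or still open, it means among the compounds named here.

In a functional assay on HL-60 cells (Homo sapiens) for inhibition, read by MTT assay, with a stated time of 72 h (on this read-out higher numbers stand for weaker inhibition and lower numbers for stronger inhibition), compound 1 (`Cc1nc(-c2ccc(F)cc2)c(C(=O)N2CCN(c3cccc(Cl)c3)CC2)o1`) gives 40.1 nM as a measured value. For the measured compounds named here, compound 2 (`COc1ccc(-c2nc(C)oc2C(=O)N2CCN(c3cccc(Cl)c3)CC2)cc1`) is reported as "not active" (no number reported) with no number attached, so it has no exact place on the scale beside compound 1 and no measured step can be taken from it. Compound 3 (`COc1cc(-c2nc(C)oc2C(=O)N2CCN(c3cccc(Cl)c3)CC2)ccc1O`) departs from compound 2 at a single aromatic carbon, where 4-hydroxy-3-methoxyphenyl stands in place of 4-methoxyphenyl (4-hydroxy-3-methoxyphenyl in place of 4-methoxyphenyl on an aromatic carbon). Going by the values given here, no measured pair shows what this change does in this assay so the size of the step remains open. Starting from compound 2, reported as "not active" (no number reported) without a figure, a modest gain in inhibition is expected, which would still leave compound 3 weaker than compound 1 at 40.1 nM in this read-out. The half-maximal inhibitory concentration of compound 3 is estimated at 3000 nM with an expected range (200 nM to 30000 nM).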

Compound 3, half-maximal inhibitory concentration: 85.9 nM
Compound 3: middle estimate off by 35-fold (1.54 log units), on the high side; measured number outside the range, below it.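

At this aromatic carbon, 4-hydroxy-3-methoxyphenyl gives compound 3 a measured number in this assay, whereas compound 2, with 4-methoxyphenyl, has none, so the step between these two cannot be read. Set against 4-fluorophenyl, the new group gives a 2.1-fold higher number from compound 1 to compound 3 (0.33 log units; beyond the scatter), so two different substituted phenyl groups at this place both give measured inhibition, separated by only a modest step. Nothing available explains why compound 2 stands apart from the other two.

Open, as far as these compounds go, is which part of the change matters: a 4-hydroxyphenyl group alone would separate the hydroxyl from the added methoxy. Also open, from the compounds shown here alone, is where a 4-aminophenyl or a 4-chlorophenyl group at this carbon would fall in this assay, and whether the 4-fluorophenyl result extends to either.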